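Swapping Bromo for Chloro: What to Expect for Compound 4

The source may hold more compounds than are shown below. What is called first, only, known or untested is meant among the compounds shown, and "the series" means these compounds.

Measured so far in an ADME assay on THP-1 cells (Homo sapiens) for cytotoxicity, read by MTT assay, with a stated time of 72 h; on this read-out higher numbers stand for lower toxicity in this test and lower numbers for higher toxicity in this test:
Compound 1, `O[C@@H]1Cc2ccccc2N[C@H](c2ccccc2)C1`: > 300000 nM, which is a limit of the test rather than a number.
Compound 2, `O[C@@H]1Cc2cc(OC(F)(F)F)ccc2N[C@H](c2ccccc2)C1`: 104000 nM.
Compound 3, `O[C@@H]1Cc2cc(Br)ccc2N[C@H](c2ccccc2)C1`: 185000 nM.

Of the two plain numbers, compound 3 has the higher one, but the gap between them is only a 1.8-fold higher number from compound 2 to compound 3 (0.25 log units; within the scatter), so the two cannot be told apart. Compound 1 sits at the limit of > 300000 nM in this assay, at which 1 of the 3 values shown sits. From there, the step of an at least 1.6-fold lower number from compound 1 to compound 3 (0.20 log units; that floor lies within the scatter) has a floor that itself lies within the scatter, whereas an at least 2.8-fold lower number from compound 1 to compound 2 (0.46 log units; beyond the scatter) goes beyond it.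

Compound 4, `O[C@@H]1Cc2cc(Cl)ccc2N[C@H](c2ccccc2)C1`, differs from compound 3 by chloro in place of bromo on an aromatic carbon. The steps that touch this position are those from compound 1 to compound 2 and from compound 1 to compound 3, both putting a substituent where there was hydrogen; the present change merely swaps one substituent for another of similar kind. Compound 4 is therefore expected to show a 1.1-fold higher number from compound 3 to compound 4 (0.03 log units; within the scatter) in this assay, a step not beyond the scatter. Compound 4 is estimated at 200000 nM, between 90000 nM and 300000 nM.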

Compound 4, half-maximal cytotoxic concentration: 188000 nM
Compound 4: middle estimate off by 1.1-fold (0.03 log units), on the high side; the range from low to high includes it.
By their numbers in this assay, from the lowest: compounds 2, 3 and 4 (each within the scatter of the next). At a limit, above all of these: compound 1.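

In this assay, putting chloro where bromo stood makes no difference that can be told from the scatter (a 1.0-fold higher number from compound 3 to compound 4 (0.01 log units; within the scatter)). The same holds for chloro in place of trifluoromethoxy (a 1.8-fold higher number from compound 2 to compound 4 (0.26 log units; within the scatter)), so compounds 2, 3 and 4, with three different substituents at this place on the ring, cannot be separated from one another. The step from hydrogen to chloro (an at least 1.5-fold lower number from compound 1 to compound 4 (0.20 log units; that floor lies within the scatter)) gives only a floor, as the value of compound 1 is a limit and not a number: the limit of > 300000 nM in this assay, at which 1 of the 4 values shown sits.

From the compounds shown here alone, it stays open whether chloro truly differs from hydrogen here, as this floor cannot settle that. Going by these compounds, it also stays open whether a quite different group at this place, such as an amine or a carboxylic acid, would stand apart from these three substituents.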